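Working notes on compound 3 and compound 4

The source may report more compounds than this note shows. Statements on the series, on what has been measured and on what is new or still open speak of the compounds shown alone.

Three compounds of the series have numbers in a functional assay on COLO 205 cells (Homo sapiens) for inhibition, read by sulforhodamine B assay, tested at 100 uM; a higher number here means more inhibition of growth at the concentration tested, a lower number less inhibition of growth. Compound 1 `COc1cc(C2CC(c3ccc(OCc4cn(Cc5ccc([N+](=O)[O-])cc5)nn4)cc3)=NN2C(C)=O)ccc1Oc1cn(Cc2ccc([N+](=O)[O-])cc2)nn1` gives 51% in this assay. Compound 2 `COc1ccc(C2CC(c3ccc(OCc4cn(Cc5ccc([N+](=O)[O-])cc5)nn4)cc3)=NN2C(C)=O)cc1` gives 37%. Compound 3 `COc1cc(C2CC(c3ccc(Br)cc3)=NN2C(C)=O)ccc1OCc1cn(Cc2ccc([N+](=O)[O-])cc2)nn1` gives 47%, which stands second highest of the three numbers; its nearest is compound 1 and its furthest compound 2, and both gaps lie within the scatter, so no order among the three can be read from this assay. Going by the values given here, no pair of the measured compounds differs in one place only, so no single-change step is available from the data.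

Compound 4 `COc1cc(C2CC(c3cc(OC)c(OC)c(OC)c3)=NN2C(C)=O)ccc1OCc1cn(Cc2ccc([N+](=O)[O-])cc2)nn1` is the next compound. It differs from compound 3 by 3,4,5-trimethoxyphenyl in place of 4-bromophenyl on a carbon with a double bond to nitrogen. Among the compounds with values here, nothing among the measured compounds shows what this change does. The step expected from compound 3 to compound 4 is a number 2 percentage points lower from compound 3 to compound 4 (within the scatter), with no direction and nothing beyond the scatter expected. For compound 4 the estimated value in this assay is 45%, with an expected range from 25% to 65%.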

Compound 4, percent growth inhibition at one concentration: 99%
Compound 4: middle estimate off by 54 percentage points, on the low side, outside the stated range (above it).
By their numbers in this assay, from the lowest: compounds 2, 3 and 1 (each within the scatter of the next, the first and the last beyond it); then compound 4.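

Going by these compounds alone, the aryl group on the carbon with a double bond to nitrogen strongly influences the read-out in this assay: 3,4,5-trimethoxyphenyl in place of 4-bromophenyl gives a number 52 percentage points higher from compound 3 to compound 4 (beyond the scatter), the first change in one place that can be read. The earlier compounds shown here offered no such pair, so they could not show that this position alone can carry a step of this size. No measurement on hand bears on why the step arises.

Open, going by these compounds, is whether all of the methoxy groups of 3,4,5-trimethoxyphenyl are needed, or whether an amine or a carboxylic acid on that phenyl ring would hold the gain. Also open, on these data alone, is whether the same change gives a comparable step on the core of compound 1 or compound 2.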